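Dropping the Phenyl Group: Expected Effect on Cell Cytotoxicity

The source may hold more compounds than are shown below. What is called first, only, known or untested is meant among the compounds shown, and "the series" means these compounds.

Three compounds were measured in a functional assay on PC-3 cells (Homo sapiens) for cytotoxicity, read by MTT assay, with a stated time of 48 h; on this read-out lower numbers stand for stronger inhibition and higher numbers for weaker inhibition:

Compound 1 `c1ccc(-c2nc(-c3c[nH]c4ccccc34)co2)cc1`: 170000 nM
Compound 2 `C(=C/c1nc(-c2c[nH]c3ccccc23)co1)\c1ccccc1`: 221000 nM
Compound 3 `Clc1ccc(-c2nc(-c3c[nH]c4ccccc34)co2)cc1`: 151000 nM

All three values lie within the scatter of one another, so compound 1 cannot be ranked against the others; its closest neighbour is compound 3, with a 1.1-fold lower number from compound 1 to compound 3 (0.05 log units; within the scatter), and compound 2 also sits within the scatter of compound 1.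

Compound 4 `c1ccc2c(-c3cocn3)c[nH]c2c1` differs from compound 1 by hydrogen in place of phenyl on an aromatic carbon. Within the data shown here, no measured step involves the same change; the only step on this core, from compound 1 to compound 3, swaps a hydrogen for chloro and stays within the scatter, and the shift from phenyl to styryl between compound 1 and compound 2 also stays within the scatter. Among the measured compounds shown here, with no guiding step, a weak compound is expected to stay weak: compound 4 is estimated at 260000 nM, a step of a 1.5-fold higher number from compound 1 to compound 4 (0.18 log units; within the scatter) in this assay, with a range from 120000 nM to 600000 nM.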

Compound 4, half-maximal inhibitory concentration: 321000 nM
For compound 4 the middle estimate is 1.2-fold (0.09 log units) below the measured one; measured number inside the range.
By their numbers in this assay, from the lowest: compounds 3, 1, 2 and 4 (each within the scatter of the next, the first and the last beyond it).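

In this assay, the phenyl group on this carbon of the five-membered ring can be replaced by plain hydrogen with no clear loss, giving a 1.9-fold higher number from compound 1 to compound 4 (0.28 log units; within the scatter) and leaving the result within the scatter. The same position shows a measurable difference only when the group removed is 4-chlorophenyl, with a 2.1-fold higher number from compound 3 to compound 4 (0.33 log units; beyond the scatter), and that difference is modest. Nothing available explains these results. Going by these compounds, whether an amine, a carboxylic acid or a longer chain at this position would bring the number clearly down remains open.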